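This account rests on a few compounds, and the source may have more. Where it says the series, first, only, none or still open, it means among the compounds named here.

Measured so far in a physicochemical assay for solubility, read by spectrophotometry, in phosphate buffer, measured as kinetic solubility, with a stated time of 18 h, at pH 7.4 (on this read-out higher numbers stand for higher solubility and lower numbers for lower solubility), are these compounds
Compound 1 `O=C(Nc1nc2ccc(Cl)cc2s1)c1cc([N+](=O)[O-])ccc1Cl` gives 1200 nM
Compound 2 `COc1ccc(-c2nc3ccccc3o2)cc1NC(=O)c1cc([N+](=O)[O-])ccc1Cl` gives 90 nM

Compound 1 holds the higher number of the two, and the gap to compound 2 lies beyond the usual scatter. Compound 3 `O=C(Nc1nc2ccc(F)cc2s1)c1cc([N+](=O)[O-])ccc1Cl` has not yet been measured. It differs from compound 1 in one place fluoro in place of chloro on an aromatic carbon with fluoro in place of chloro on an aromatic carbon, on a six-membered aromatic ring of carbon only that is part of a fused system of two rings. Among the measured compounds shown here, no measured pair shows this change, so the expectation starts from compound 1 at 1200 nM and is only a judgement. In this assay a small upward step is expected, close to the scatter. Compound 3 is estimated at 2000 nM with an expected range from 600 nM to 7000 nM in repeated measurements. This estimate means an expected step of a 1.7-fold higher number from compound 1 to compound 3 (0.22 log units; within the scatter) and no more than that.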

Compound 3, solubility: 570 nM
The estimate for compound 3 lay 3.5-fold (0.55 log units) above the measured number; the whole stated range lies above it.
By their numbers in this assay, from the lowest: compound 2; then compound 3; then compound 1.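

In this assay, fluoro in place of chloro on the aromatic carbon of the six-membered ring in the fused system gives a 2.1-fold lower number from compound 1 to compound 3 (0.32 log units; beyond the scatter), a modest step. This position of the core of compound 1 therefore registers the exchange of one heavy atom for another, with no change in rings, net charge or counted hydrogen-bond donors and acceptors. Compound 1 and compound 2 differ in more than one place and could not show this, and nothing measured here explains the step.

Among the compounds shown here, this single pair gives only one step at this position, so no trend can be drawn from it. Going by these compounds, how an amine, a nitrile or a carboxylic acid at the same aromatic carbon would compare with chloro and fluoro remains open.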